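Kallikrein-7 inhibitors: trimming the sulfonyl aryl group

The compounds below may be only part of what the source reports. "The series", "measured", "known", "first", "only" and "open" are said of these compounds alone.

Measured compounds:
Compound 1, `CCC1=NC(c2cn(S(=O)(=O)c3ccc(C)cc3)c3ccccc23)CN1`, gives 24000 nM in an assay on isolated protein for inhibition of kallikrein-7 (Homo sapiens), read by fluorescence, with stated times of 10 min and 30 min; a lower number here means a stronger inhibitor, a higher number a weaker inhibitor.
Compound 2, `CC1=NC(c2cn(S(=O)(=O)c3ccc(Cl)cc3)c3ccccc23)CN1`, gives 5700 nM in this assay.

Going by the values given here, compound 2 holds the lower of the two numbers in this assay; compound 1 is the only neighbour, and the two values stand apart by more than the scatter. Among the compounds with values here, no step between measured compounds differing in one place is available, so the two values can only be read side by side.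

Compound 3, `CC1=NC(c2cn(S(C)(=O)=O)c3ccccc23)CN1`, is not yet measured. It differs from compound 2 by methyl in place of 4-chlorophenyl on a sulfonyl sulfur. Within the data shown here, with no measured step of this kind to lean on, the change from compound 2 to compound 3 is expected to weaken inhibition in this assay, as a step of moderate size, a 3.5-fold higher number from compound 2 to compound 3 (0.55 log units; beyond the scatter). Compound 3 is therefore estimated at 20000 nM, within a range from 6000 nM to 80000 nM.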

Compound 3, half-maximal inhibitory concentration: > 100000 nM
Compound 3 was reported as a limit; the forecaster's own chance of this, stated with the estimate: 15%; at least 5.0-fold (0.69 log units) between middle value and limit.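

Methyl in place of 4-chlorophenyl on a sulfonyl sulfur gives an at least 17-fold higher number from compound 2 to compound 3 (1.24 log units; beyond the scatter) in this assay, the first change at a single place in this series, and it shows that inhibition depends strongly on the group held at this position. Of the two groups, only 4-chlorophenyl gives a value that can be read in this assay, so the shared core with methyl on the sulfonyl sulfur is not enough for measurable inhibition here. The true size of the step stays unknown, since compound 3 stands at a limit and not at a number: the limit of > 100000 nM in this assay, at which 1 of the 3 values shown sits.

The compounds shown leave open whether the loss follows from removing the aromatic ring or only its chlorine, which plain phenyl on the sulfonyl sulfur would separate. They also leave open how a benzyl group, a longer alkyl chain or an amine-bearing aryl group would fare at this position.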